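The source may hold more compounds than are shown below. What is called first, only, known or untested is meant among the compounds shown, and "the series" means these compounds.

Working notes on the series.

Compound 1 `COc1ccc(-c2cc(/C=C/C(=O)c3ccc(N)cc3)[nH]n2)cc1` and compound 2 `COc1cc(-c2cc(/C=C/C(=O)c3ccc(Cl)c(Cl)c3)[nH]n2)cc(OC)c1OC` share the same core and the same enone link; they differ in the ring on the carbonyl and in the substitution of the other aryl ring, so no single-point comparison exists between them. In a functional assay on HCT-116 cells (Homo sapiens) for cytotoxicity, read by sulforhodamine B assay, with a stated time of 48 h, tested at 10 uM (on this read-out higher numbers stand for a weaker effect at the one concentration tested and lower numbers for a stronger effect), compound 1 gives -53%. In this assay, within the data shown here, compound 2 gives 16%, the highest of the two numbers so far and beyond the scatter from compound 1; with only two compounds, no further ordering is possible.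

Compound 3 `COc1cc(-c2cc(/C=C/C(=O)c3ccc(F)c(F)c3)[nH]n2)cc(OC)c1OC` is the next point. Its difference from compound 2 is a single change on the carbonyl carbon: 3,4-difluorophenyl in place of 3,4-dichlorophenyl on a carbonyl carbon. Among the measured compounds shown here, no measured pair in the set covers this change, so the size of the step is unknown. The expectation is a small step, within or near the scatter, with a lean toward a weaker effect; an estimated step of a number 6 percentage points higher from compound 2 to compound 3 (within the scatter) is assumed. Compound 3 is therefore expected at about 22%, in a range from -15% to 55%.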

Compound 3, a percentage reported as activity, at one concentration (the size of the read-out at that concentration, not a potency): 9%
Compound 3: the middle estimate sits 13 percentage points above what was measured, and the stated range covers the measured number.
By their numbers in this assay, from the lowest: compound 1; then compounds 3 and 2 (each within the scatter of the next).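

In this assay, among these compounds, the exchange of 3,4-dichlorophenyl for 3,4-difluorophenyl on a carbonyl carbon gives a number 7 percentage points lower from compound 2 to compound 3 (within the scatter), the first step that can be read at a single place. At this one concentration, the two halogen-bearing rings are therefore not told apart on the background shared by compound 2 and compound 3, and this place tolerates this exchange without a step beyond the scatter. No measurement at hand bears on why the step has this size.

Only this one exchange has been read at this place, so the compounds shown do not tell whether a plain phenyl or a phenyl carrying a nitrile or a trifluoromethyl group would also stay within the scatter of compound 2, or whether the same exchange would give a similar step on another background. Compound 1 differs from compound 2 and compound 3 in more than one place, so the steps for its amino-bearing ring and for the substitution of its other aryl ring cannot be read.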